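This account rests on a few compounds, and the source may have more. Where it says the series, first, only, none or still open, it means among the compounds named here.

Compound 1, `CCNc1nc(-c2ccccc2)nc2c1nnn2Cc1ccccc1Cl`, in an assay on isolated protein for binding affinity to adenosine receptor A1 (Bos taurus); a lower number here means a stronger inhibitor, a higher number a weaker inhibitor: 463000000 nM
Compound 2, `Clc1ccccc1Cn1nnc2c(NC3CC3)nc(-c3ccccc3)nc21`, in this assay: 11000000 nM
Compound 3, `Clc1ccccc1Cn1nnc2c(NC3CCCC3)nc(-c3ccccc3)nc21`, in this assay: 9000000 nM

Compound 3 holds the lowest number of the three in this assay, but its separation from compound 2 is only a 1.2-fold lower number from compound 2 to compound 3 (0.09 log units; within the scatter), which falls within the scatter, so the two cannot be ordered. Both stand far from compound 1: a 42-fold lower number from compound 1 to compound 2 (1.62 log units; beyond the scatter) and a 51-fold lower number from compound 1 to compound 3 (1.71 log units; beyond the scatter), each a large step that comes with a ring in place of ethyl on the nitrogen.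

Compound 4, `CC(O)CNc1nc(-c2ccccc2)nc2c1nnn2Cc1ccccc1Cl`, differs from compound 3 by 2-hydroxypropyl in place of cyclopentyl on a nitrogen on an aromatic ring. Among the measured compounds shown here, no measured pair shows this exact exchange. The bearing steps are those from compound 1, where the acyclic ethyl sat on that nitrogen and the number was far higher, and the step from compound 2 to compound 3, which shows that the size of the ring hardly mattered. Compound 4 returns to an acyclic group, now carrying a hydroxyl whose effect nothing here reveals. Compound 4 is therefore expected to move back toward compound 1, by an 8.9-fold higher number from compound 3 to compound 4 (0.95 log units; beyond the scatter), with wide uncertainty. The estimate for compound 4 in this assay is 80000000 nM, within 9000000 nM to 500000000 nM.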

Compound 4, inhibition constant: 32000000 nM
Beside the measured number, compound 4's estimate is 2.5-fold (0.40 log units) above it; the range from low to high includes it.
By their numbers in this assay, from the lowest: compounds 3 and 2 (each within the scatter of the next); then compound 4; then compound 1.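

On the nitrogen on an aromatic ring, an open chain does not by itself bring the number back up to that of compound 1: in this assay, adding a hydroxyl-bearing carbon unit to the ethyl chain gives a 14-fold lower number from compound 1 to compound 4 (1.16 log units; beyond the scatter), a large step made without any ring. The rings still keep a modest edge over this chain, with a 3.6-fold higher number from compound 3 to compound 4 (0.55 log units; beyond the scatter) and a 2.9-fold higher number from compound 2 to compound 4 (0.46 log units; beyond the scatter), so the 2-hydroxypropyl group places compound 4 on the side of compounds 2 and 3 while leaving it separate from both, and the earlier contrast of ring against open chain no longer describes this position on its own. No outside information accounts for these steps, so the reason for them stays unknown.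

The compounds shown do not separate the contribution of the hydroxyl from that of the longer, branched chain, and a plain propyl group on the same nitrogen would draw that line. On these data alone, it also remains open whether another group at the same carbon, such as an amine or a methoxy group, would match the hydroxyl, and whether a hydroxyl on a cyclopentyl ring would add to what the ring gives.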